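The source may report more compounds than this note shows. Statements on the series, on what has been measured and on what is new or still open speak of the compounds shown alone.

Compound 1 `CCNC(=O)c1noc(-c2cc(C(C)C)c(O)cc2O)c1-c1cc(COCC(=O)OC)no1` gives 262 nM in a functional assay on HCT-116 cells (Homo sapiens) for inhibition; a lower number here means a stronger inhibitor, a higher number a weaker inhibitor.
Compound 2 `CCCNCc1cc(-c2c(C(=O)NCC)noc2-c2cc(C(C)C)c(O)cc2O)on1` gives 117 nM in this assay.

Going by the values given here, compound 2 stands with the lowest of the two numbers in this assay; the only measured step, a 2.2-fold lower number from compound 1 to compound 2 (0.35 log units; beyond the scatter), separates it from compound 1. Compound 3 `CCNC(=O)c1noc(-c2cc(C(C)C)c(O)cc2O)c1-c1cn[nH]c1` differs from compound 2 by 1H-pyrazol-4-yl in place of 3-((propylamino)methyl)-1,2-oxazol-5-yl on an aromatic carbon. That measured step concerns a different part of the structure, so nothing measured covers the change to compound 3 directly, and only a modest shift is expected, most likely toward a higher number. The expected step is a 3.0-fold higher number from compound 2 to compound 3 (0.48 log units; beyond the scatter). Compound 3 is thus estimated at 350 nM, with a range from 120 nM to 1000 nM.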

Compound 3, half-maximal inhibitory concentration: 43 nM
For compound 3 the middle estimate is 8.1-fold (0.91 log units) above the measured one; measured number outside the range, below it.
By their numbers in this assay, from the lowest: compound 3; then compound 2; then compound 1.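

At this position on the aromatic carbon, the whole 3-((propylamino)methyl)-1,2-oxazol-5-yl group can give way to the smaller 1H-pyrazol-4-yl, and in this assay the number falls further, with a 2.7-fold lower number from compound 2 to compound 3 (0.43 log units; beyond the scatter) beyond the scatter. The earlier step altered only the chain on the ring, whereas this one replaces ring and chain together, so the propylamino chain is not required for this level of inhibition. No evidence at hand explains the shift.

The two parts of the change remain unseparated, since the ring and the chain left together. From the compounds shown here alone, how a plain phenyl ring or a 1H-pyrazol-4-yl carrying a propylamino chain would read at this position stays open.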